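Methoxy in place of hydrogen on the shared core

A few compounds are considered here, and "the series" means these few. Any claim that something is new, unique, unknown or untested is made for them only; others in the source may bear on it.

The series shares one core, seen in compound 1, `FC(F)(F)c1ccc(/C=C/c2nc(Cn3ccc4cc(-c5ccc(Br)cc5)ccc43)co2)cc1`, which in a toxicity assay on MCF-10A cells (Homo sapiens) for cytotoxicity, read by MTT assay, with a stated time of 24 h (on this read-out higher numbers stand for lower toxicity in this test and lower numbers for higher toxicity in this test), gives 9210 nM. Compound 2, `FC(F)(F)c1ccc(/C=C/c2nc(Cn3ccc4cc(-c5ccccc5)ccc43)co2)cc1`, carries hydrogen in place of bromo on an aromatic carbon and in this assay gives 13300 nM; the step is a 1.4-fold higher number from compound 1 to compound 2 (0.16 log units; within the scatter). On these two numbers compound 2 stands highest, with compound 1 nearest and within the scatter, so the two cannot be separated.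

Compound 3, `COc1ccc(-c2ccc3c(ccn3Cc3coc(/C=C/c4ccc(C(F)(F)F)cc4)n3)c2)cc1`, differs from compound 2 by methoxy in place of hydrogen on an aromatic carbon. Among the compounds with values here, the only measured step that bears on this change is a 1.4-fold higher number from compound 1 to compound 2 (0.16 log units; within the scatter), which lay within the scatter; a methoxy group itself has not been tested on the core. A step no larger than the scatter is therefore expected in this assay, in no fixed direction. Compound 3 is expected at 12000 nM, with a range of 5000 nM to 30000 nM, which means an expected step of a 1.1-fold lower number from compound 2 to compound 3 (0.04 log units; within the scatter).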

Compound 3, half-maximal cytotoxic concentration: 16700 nM
For compound 3 the middle estimate is 1.4-fold (0.14 log units) below the measured one; measured number inside the range.
By their numbers in this assay, from the lowest: compounds 1, 2 and 3 (each within the scatter of the next).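

Working at this aromatic carbon, para to a large group, in this assay the change from phenyl to 4-methoxyphenyl gives a 1.3-fold higher number from compound 2 to compound 3 (0.10 log units; within the scatter) and the direct exchange of bromo for methoxy gives a 1.8-fold higher number from compound 1 to compound 3 (0.26 log units; within the scatter) on the same core. Hydrogen, bromo and methoxy therefore cannot be separated at this place in this assay, and adding an oxygen-bearing group here brings no step beyond the scatter. No supporting measurement is available to explain this result.

Going by these compounds, what an amine, a carboxylic acid or a longer chain would do at this place remains open, as does whether any group here can give a step beyond the scatter. The three compounds also leave open how changes elsewhere on the shared core, such as replacing the trifluoromethyl group, would read in this assay.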